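Swapping the Aryl End Group of Compound 2

A few compounds are considered here, and "the series" means these few. Any claim that something is new, unique, unknown or untested is made for them only; others in the source may bear on it.

Compound 1 `CC1=C(/C=C/C(=O)/C=C/c2ccc(F)cc2)C(C)(C)CCC1` gives 32200 nM in a functional assay on HeLa cells (Homo sapiens) for cytotoxicity, read by sulforhodamine B assay, with a stated time of 48 h; on this read-out higher numbers stand for weaker inhibition and lower numbers for stronger inhibition. Compound 2 `CC1=C(/C=C/C(=O)/C=C/c2ccccc2C)C(C)(C)CCC1` reaches only the limit of this assay, > 100000 nM, in this assay. For the measured compounds named here, the single measured step, an at least 3.1-fold higher number from compound 1 to compound 2 (0.49 log units; beyond the scatter), is bounded by the limit of > 100000 nM in this assay, at which 1 of the 2 values shown sits. Compound 3 `CC1=C(/C=C/C(=O)/C=C/c2ccoc2)C(C)(C)CCC1` differs from compound 2 by furan-3-yl in place of 2-methylphenyl on a double-bonded chain carbon bound to a double-bonded chain carbon. Going by the values given here, no measured step covers this change, and compound 2 stands at a limit, so the expected step of an at least 1.2-fold lower number from compound 2 to compound 3 (0.09 log units; that floor lies within the scatter) in this assay is taken as small and of uncertain direction. Compound 3 is therefore estimated at 80000 nM, between 25000 nM and 250000 nM.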

Compound 3, half-maximal inhibitory concentration: 88400 nM
Compound 3: middle estimate off by 1.1-fold (0.04 log units), on the low side, within the range that was stated.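

Furan-3-yl on a double-bonded chain carbon bound to a double-bonded chain carbon gives a measured number in this assay, and in place of 4-fluorophenyl it brings a 2.7-fold higher number from compound 1 to compound 3 (0.44 log units; beyond the scatter). Weaker inhibition than with 4-fluorophenyl therefore appears with two different end groups, 2-methylphenyl and furan-3-yl, not with one alone. Against 2-methylphenyl the change reads an at least 1.1-fold lower number from compound 2 to compound 3 (0.05 log units; that floor lies within the scatter), so no order can be given for this pair, whose reading is bounded: the limit of > 100000 nM in this assay, at which 1 of the 3 values shown sits.

Still open, going by these compounds, is the true value of compound 2. Also open, on these data alone, is whether a phenyl ring carrying an amine or a carboxylic acid at this place would match or pass 4-fluorophenyl.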